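Same chlorines, rearranged on the benzyl group

This account rests on a few compounds, and the source may have more. Where it says the series, first, only, none or still open, it means among the compounds named here.

Measured so far in a functional assay on HL-60 cells (Homo sapiens) for antiproliferative activity, with a stated time of 24 h; on this read-out higher numbers stand for weaker inhibition and lower numbers for stronger inhibition
- compound 1 `NC(=O)c1c(NC(=O)c2ccccc2Cl)sc2c1CCN(Cc1ccccc1)C2` gives 12000 nM
- compound 2 `NC(=O)c1c(NC(=O)c2ccccc2Cl)sc2c1CCN(Cc1c(Cl)cccc1Cl)C2` gives 4850 nM

Of these two, compound 2 has the lower number (4850 nM) and so inhibits more strongly. Compound 3 `NC(=O)c1c(NC(=O)c2ccccc2Cl)sc2c1CCN(Cc1cc(Cl)cc(Cl)c1)C2` has the same atoms joined differently (3,5-dichlorophenyl in place of 2,6-dichlorophenyl on a saturated chain carbon bound to an amine nitrogen in a ring). Among the compounds with values here, only one measured step bears on this change. It is a 2.5-fold lower number from compound 1 to compound 2 (0.39 log units; beyond the scatter) and it is modest, which gives a guide to size only. Within the data shown here, no measured compound carries the 3,5-dichlorophenyl, so the data give no firm direction. A step no larger than that modest one is therefore expected in this assay with only a slight lean towards a higher number. The estimated change is a 1.2-fold higher number from compound 2 to compound 3 (0.09 log units; within the scatter) and may well stay within the scatter. Compound 3 is expected at 6000 nM with an estimated range from 2000 nM to 15000 nM in this assay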

Compound 3, half-maximal inhibitory concentration: 15800 nM
Compound 3: the middle estimate sits 2.6-fold (0.42 log units) below what was measured; the measured number lies above the stated range.
By their numbers in this assay, from the lowest: compound 2; then compounds 1 and 3 (each within the scatter of the next).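

Swapping the 2,6-dichlorophenyl for the 3,5-dichlorophenyl on this carbon changes the result in this assay (a 3.3-fold higher number from compound 2 to compound 3 (0.51 log units; beyond the scatter)), so the same two chlorines do not give the same number once rearranged. The 3,5-dichlorophenyl also stays level with the plain phenyl (a 1.3-fold higher number from compound 1 to compound 3 (0.12 log units; within the scatter)), which leaves compound 2 as the only one of the three standing apart, and adding chlorines does not by itself lower the number. No measurement at hand explains why the arrangement of the chlorines matters.

From the compounds shown here alone, whether a phenyl carrying a single chlorine would already lower the number remains open. So does whether a 2,6-dimethylphenyl or 2,6-dimethoxyphenyl would match the 2,6-dichlorophenyl, or whether a longer chain to the ring would keep the effect.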